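This account rests on a few compounds, and the source may have more. Where it says the series, first, only, none or still open, it means among the compounds named here.

Working notes on the series, read in a physicochemical assay for lipophilicity, read by LC-MS, in phosphate buffer, measured as octanol-water partition, with a stated time of 30 min, at pH 7.4, tested at 200 mM; on this read-out lower numbers stand for lower lipophilicity and higher numbers for higher lipophilicity. Compound 1 (`Cn1c(COc2cccc(C(=O)O)c2)nc2ccc(Oc3ccc4c(c3)OCC4)nc21`) gives 1.4, compound 2 (`Cn1c(COc2cccc(C(=O)O)c2)nc2ccc(Oc3ccccn3)cc21`) gives 0.4 and compound 3 (`Cn1c(COc2cccc(C(=O)O)c2)nc2ccc(Oc3cc(Cl)ccn3)cc21`) gives 1.2. Compound 3 therefore stands within the scatter of compound 1 and beyond the scatter above compound 2.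

Compound 4 (`Cc1ccc(Oc2ccc3nc(COc4cccc(C(=O)O)c4)n(C)c3c2)nc1`) has not yet been measured. Its structural difference from compound 3 is 5-methylpyridin-2-yl in place of 4-chloropyridin-2-yl on an oxygen on an aromatic ring.

Going by the values given here, one measured step bears on this change: a number 0.80 log units higher from compound 2 to compound 3 (beyond the scatter), with chloro in place of hydrogen on an aromatic carbon. That step is modest and covers the chloro group only. Among the compounds with values here, no measured compound carries 5-methylpyridin-2-yl, so the methyl group has no measured step of its own in these data. Compound 4 still carries a substituent on that ring, so its number is expected to stay nearer compound 3 at 1.2 than compound 2 at 0.4. In this assay the expected change is small and downward, a number 0.20 log units lower from compound 3 to compound 4 (within the scatter). For compound 4 the estimate is 1, with an expected range from 0.6 to 1.4.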

Compound 4, distribution coefficient: 0.9
For compound 4 the middle estimate is 0.10 log units above the measured one; low and high end bracket the measured number.
By their numbers in this assay, from the lowest: compound 2; then compounds 4, 3 and 1 (each within the scatter of the next, the first and the last beyond it).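

In this assay the methyl group now has a measured step of its own, which reads a number 0.50 log units higher from compound 2 to compound 4 (beyond the scatter) and so a substituent other than chloro on this ring also stands apart from compound 2, which carries hydrogen there. Within these three compounds both substituents go the same way from compound 2, with none going against it, as chloro in place of hydrogen gives a number 0.80 log units higher from compound 2 to compound 3 (beyond the scatter) in the same direction. The direct exchange of 5-methylpyridin-2-yl for 4-chloropyridin-2-yl on an oxygen on an aromatic ring gives a number 0.30 log units lower from compound 3 to compound 4 (within the scatter) and so this assay does not tell these two rings apart.

That exchange alters both the group and its place on the ring, and the compounds shown hold neither group at the other's place, so the two changes cannot be separated, while a group of another kind on this ring, such as an amine or a methoxy group, remains open. No measurement on hand gives a reason for any of these steps.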